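The source may report more compounds than this note shows. Statements on the series, on what has been measured and on what is new or still open speak of the compounds shown alone.

Three compounds have numbers in a functional assay on KB cells (Homo sapiens) for cytotoxicity, read by spectrophotometry and crystal violet staining; on this read-out higher numbers stand for weaker inhibition and lower numbers for stronger inhibition:

Compound 1 `COC(=N)c1c(Cl)n(C2O[C@H](CO)[C@@H](O)[C@H]2O)c2cc(Cl)c(Cl)cc12` gives 50000 nM.
Compound 2 `N/C(S)=N/N=C/c1c(Cl)n(C2O[C@H](CO)[C@@H](O)[C@H]2O)c2cc(Cl)c(Cl)cc12` gives 65000 nM.
Compound 3 `OC[C@H]1O[C@@H](n2c(Br)nc3cc(Cl)c(Cl)cc32)[C@H](O)[C@@H]1O` reaches only the limit > 100000 nM, which is a limit of the assay and not a number.

Compound 2 therefore sits beside compound 1: the step of a 1.3-fold higher number from compound 1 to compound 2 (0.11 log units; within the scatter) stays within the scatter, so the two cannot be told apart, and compound 3 adds no number at all, only its limit (the limit of > 100000 nM in this assay, at which 1 of the 3 values shown sits).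

Compound 4 `NC(=O)N/N=C/c1c(Cl)n(C2O[C@H](CO)[C@@H](O)[C@H]2O)c2cc(Cl)c(Cl)cc12` has not yet been measured in this assay. It differs from compound 2 by a group of 4 heavy atoms (1 carbon, 2 nitrogen, 1 oxygen; no ring) in place of a group of 4 heavy atoms (1 carbon, 2 nitrogen, 1 sulfur; no ring), on a double-bonded nitrogen, in other words the sulfur of the side group is exchanged for oxygen, giving the ureido group on the double-bonded nitrogen. Among the compounds with values here, no measured step touches this position; the only measured step, from compound 1 to compound 2, changes a different part of the molecule and itself lies within the scatter. The numbers seen here are all large and close together, so no step beyond the scatter is expected for this exchange.

Compound 4 is thus estimated at 65000 nM, between 30000 nM and 150000 nM, meaning an expected step of no change at the digits printed from compound 2 to compound 4 (within the scatter).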

Compound 4, half-maximal inhibitory concentration: > 100000 nM
Compound 4: only a limit was reported; the forecaster's own chance of this, stated with the estimate: 35%; middle value at least 1.5-fold (0.18 log units) away from the limit.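

Compound 4 gives > 100000 nM in this assay, which is a limit of the assay and not a number. The earlier compounds shown here offered no step at this position, and exchanging sulfur for oxygen, which places the ureido group on the double-bonded nitrogen, now gives an at least 1.5-fold higher number from compound 2 to compound 4 (0.18 log units; that floor lies within the scatter), while replacing the side group of compound 1 with the full ureido-bearing chain gives an at least 2.0-fold higher number from compound 1 to compound 4 (0.30 log units; that floor lies within the scatter). Both steps are floors that lie within the scatter, so the data show only that the sulfur-bearing compound 2 has a measured number while its oxygen partner does not, and that this exchange brings no visible gain in strength, on a read-out where the top end is already crowded: the limit of > 100000 nM in this assay, at which 2 of the 4 values shown sit.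

From the compounds shown here alone, the true size of the sulfur-to-oxygen step stays unknown, as does whether it would look the same on a core that gives stronger numbers. Going by these compounds, it also remains open how the double-bonded nitrogen would respond to a different group, such as a simple amine or a longer carbon chain, in place of the ureido group.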